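A few compounds are considered here, and "the series" means these few. Any claim that something is new, unique, unknown or untested is made for them only; others in the source may bear on it.

Of the compounds shown here, three have so far been tested in an ADME assay on microsomes from liver (Rattus norvegicus) for metabolic stability, with a stated time of 10 min; a higher number here means that more of the compound is left, a lower number that less of the compound is left. Compound 1 (`COc1cc(OCc2ccccc2OC)c2cc(-c3cn4nc(OC)sc4n3)oc2c1`) gives 28%, compound 2 (`CCSc1nn2cc(-c3cc4ccccc4o3)nc2s1`) gives 35%, and compound 3 (`COc1cc(OCc2cccc(CCc3ccccc3)c2)c2cc(-c3cn4nc(OC)sc4n3)oc2c1`) gives 68%. Compound 2 and compound 1 lie within the usual scatter of each other, so the two cannot be told apart on these numbers. Compound 3 stands above them both, and that gap lies beyond the scatter.

The next compound to be measured is compound 4 (`Cc1nn2cc(-c3cc4ccccc4o3)nc2s1`), which differs from compound 2 in a single place: methyl in place of ethylsulfanyl on an aromatic carbon. Methyl takes the place of ethylsulfanyl on an aromatic carbon of the five-membered aromatic ring, and the rest of the structure stays the same. Among the measured compounds shown here, no measured pair in this small set differs in one place only, so the data offer no direct guide to the size of such a step. With compound 2 at 35%, there is room for movement in either direction, and a modest rise in this assay is expected, one that may not clear the scatter. The estimated step is a number 10 percentage points higher from compound 2 to compound 4 (within the scatter). For compound 4 the expected value is 45%, with an estimated range from 25% to 65%.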

Compound 4, percent of the compound remaining: 4%
Beside the measured number, compound 4's estimate is 41 percentage points above it, outside the stated range (below it).
By their numbers in this assay, from the lowest: compound 4; then compounds 1 and 2 (each within the scatter of the next); then compound 3.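

In this assay, the aromatic carbon of the five-membered aromatic ring, next to the ring nitrogen and next to the ring sulfur, proves sensitive to the group it carries: methyl in place of ethylsulfanyl gives a number 31 percentage points lower from compound 2 to compound 4 (beyond the scatter). Among the compounds shown here, this is the first single-place step in the set, and the earlier compounds, which differ from one another in more than one place, could not show how much a change at this position alone can matter. Here the smaller group goes with much less of the compound remaining, but no measurement at hand explains why the number falls.

The two compounds leave open whether the step follows the sulfur or the length of the chain, as the change removes both at once; ethyl, methylsulfanyl or propylsulfanyl at the same carbon would separate the two, and an amine or a methoxy group there would show whether the link to the ring matters more widely. On these data alone, it also remains open whether a step of this size would carry over to the core of compound 1 or compound 3, as a single pair cannot establish a trend for this position.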